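Demethylation of the phenol in the dienamide series

The source may report more compounds than this note shows. Statements on the series, on what has been measured and on what is new or still open speak of the compounds shown alone.

Compound 3 `COc1cc(/C=C/C=C/C(=O)N2CCCCC2)ccc1O` gives 55.5% in an assay for inhibition of Polyunsaturated fatty acid 5-lipoxygenase (Homo sapiens), read by spectrophotometry, tested at 20 uM (a lower number here means less inhibition, a higher number more inhibition at the concentration tested (going by the name of the read-out)), and stands highest of the three compounds measured. Compound 1 `COc1cc(/C=C/C=C/C(=O)N2CCCCC2)cc(OC)c1O` gives 32.7%, and compound 2 `O=C(/C=C/C=C/C=C/c1ccc(O)c(O)c1)N1CCCCC1` gives 30.3%; both gaps to compound 3 lie beyond the scatter. Going by the values given here, the only step within the set, a number 22.8 percentage points higher from compound 1 to compound 3 (beyond the scatter), shows that removing one methoxy group from the aromatic ring of compound 1 raised inhibition by a modest amount.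

Compound 4 `O=C(/C=C/C=C/c1ccc(O)c(O)c1)N1CCCCC1` arises from compound 3 by hydrogen in place of methyl on an oxygen on an aromatic ring. Among the compounds with values here, no measured step covers this particular change. Compound 2 carries the same hydroxy pair on its aromatic ring but a longer chain, so its value can only be noted alongside, not used as a step. On that basis the step is expected to be small or at most a modest decline, with a wide range. Compound 4 is estimated at 45% (range 25% to 65%), which would mean a step of a number 10.5 percentage points lower from compound 3 to compound 4 (beyond the scatter).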

Compound 4, a percentage reported as inhibition, at one concentration (the size of the read-out at that concentration, not a potency): 82.8%
For compound 4 the middle estimate is 37.8 percentage points below the measured one, and the stated range ends below it.
By their numbers in this assay, from the lowest: compounds 2 and 1 (each within the scatter of the next); then compound 3; then compound 4.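

Replacing the methyl with hydrogen on an oxygen on an aromatic ring gives a number 27.3 percentage points higher from compound 3 to compound 4 (beyond the scatter) in this assay, so inhibition responds to methoxy to hydroxy as well as to the outright loss of a methoxy group, which gave a number 22.8 percentage points higher from compound 1 to compound 3 (beyond the scatter). Along these two steps, each single change to the aromatic ring raises inhibition, and compound 4 stands highest of the four compounds. Nothing available accounts for this rise.

Going by these compounds alone, compound 2 carries the same hydroxy pair on a longer chain and gives 30.3%, but no single step isolates the effect of chain length. Going by these compounds, it remains open whether an ethoxy group, an amine or a carboxylic acid in place of this hydroxy would keep inhibition at the level of compound 4.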